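Replacing (methylsulfonyl)methyl with sulfamoyl in compound 2

The source may report more compounds than this note shows. Statements on the series, on what has been measured and on what is new or still open speak of the compounds shown alone.

Values so far in a functional assay on HUVEC cells (Homo sapiens) for inhibition (a lower number here means a stronger inhibitor, a higher number a weaker inhibitor), are these
compound 1 `CN(c1ccc(NC(=O)Nc2ccccc2)cc1)c1ccnc(Nc2cccc(S(N)(=O)=O)c2)n1` with 2 nM
compound 2 `CN(c1ccc(NC(=O)Nc2ccc(OC(F)(F)F)cc2)cc1)c1ccnc(Nc2cccc(CS(C)(=O)=O)c2)n1` with 7 nM

Of these two numbers, compound 2 (7 nM) holds the higher one, and its gap to compound 1 lies beyond the scatter. The two compounds differ in more than one place, so the gap cannot be assigned to any single change.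

Compound 3 `CN(c1ccc(NC(=O)Nc2ccc(OC(F)(F)F)cc2)cc1)c1ccnc(Nc2cccc(S(N)(=O)=O)c2)n1` keeps the rest of compound 2 but carries sulfamoyl in place of (methylsulfonyl)methyl on an aromatic carbon, meta to a large group (sulfamoyl in place of (methylsulfonyl)methyl on an aromatic carbon). For the measured compounds named here, no measured pair shows this change alone, so its size in this assay is not known from the data. Compound 1 also carries sulfamoyl and gives the lower number (2 nM), which points to a modest fall rather than a rise. The expected step (a 2.3-fold lower number from compound 2 to compound 3 (0.37 log units; beyond the scatter)) is therefore small and may lie close to the edge of the scatter. The estimate for compound 3 is 3 nM (expected range 1 nM to 9 nM).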

Compound 3, half-maximal inhibitory concentration: 5 nM
Compound 3: middle estimate off by 1.7-fold (0.22 log units), on the low side, and the stated range covers the measured number.
By their numbers in this assay, from the lowest: compound 1; then compounds 3 and 2 (each within the scatter of the next).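

In this assay, the change at this aromatic carbon can now be read on its own. Replacing (methylsulfonyl)methyl with sulfamoyl gives a 1.4-fold lower number from compound 2 to compound 3 (0.15 log units; within the scatter), so this read-out does not separate the two groups at this position, although sulfamoyl carries a hydrogen-bond donor and (methylsulfonyl)methyl carries none. Compound 3 also isolates a second change, with sulfamoyl held fixed: trifluoromethoxy in place of hydrogen on an aromatic carbon gives a 2.5-fold higher number from compound 1 to compound 3 (0.40 log units; beyond the scatter), and of the two single changes now readable, only this modest one lies beyond the scatter. Nothing in the available data accounts for either step.

As far as these compounds go, it remains open whether the position would accept groups of a different kind, such as a carboxylic acid, an amine or a longer chain, as readily as it accepts these two. From the compounds shown here alone, it is also open how a chlorine or a methyl would compare with trifluoromethoxy at the carbon where that group sits, and so whether the step seen there is particular to trifluoromethoxy.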